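A few compounds are considered here, and "the series" means these few. Any claim that something is new, unique, unknown or untested is made for them only; others in the source may bear on it.

Working notes on the series. Compound 1 `Fc1ccc(Cc2ccc3c(NCCCNCc4ccco4)ccnc3c2)cc1` and compound 2 `Fc1ccc(Cc2ccc3c(NCCCNCc4ccco4)ccnc3c2)c(Cl)c1` share one core; compound 3 `COc1ccc(F)cc1CNCCCNc1ccnc2cc(Oc3ccccc3)ccc12` and compound 4 `COc1ccc(F)cc1CNCCCNc1ccnc2cc(Oc3ccc(Cl)cc3)ccc12` share another. The difference between the two cores is not broken down here. In an ADME assay for permeability, using PAMPA, with a stated time of 30 min, at pH 7.4 (on this read-out higher numbers stand for higher permeability and lower numbers for lower permeability), compound 1 gives 23 10^-6 cm/s, and compound 2 gives 23 10^-6 cm/s. The change chloro in place of hydrogen on an aromatic carbon gave no change at the digits printed from compound 1 to compound 2 (within the scatter). Compound 3 gives 317 10^-6 cm/s, which is the highest of the three values. Compound 4 carries the change (chloro in place of hydrogen on an aromatic carbon), the same kind of change as in compound 2, though not the same: in compound 2 the chloro sits ortho to a large group and meta to a fluoro group, in compound 4 para to a large group. The step of a 1.1-fold lower number from compound 3 to compound 4 (0.02 log units; within the scatter) is expected to be small, due to no change at the digits printed from compound 1 to compound 2 (within the scatter). Compound 4 is expected at 300 10^-6 cm/s, between 150 10^-6 cm/s and 600 10^-6 cm/s, in this assay.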

Compound 4, apparent permeability: 317 10^-6 cm/s
Compound 4: middle estimate off by 1.1-fold (0.02 log units), on the low side; the measured number falls inside the stated range.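

In this assay, chloro in place of hydrogen on an aromatic carbon gave no change at the digits printed from compound 3 to compound 4 (within the scatter), and the step reads the same on both cores: the same change on two cores in this assay, no change at the digits printed (within the scatter) from compound 1 to compound 2 and no change at the digits printed (within the scatter) from compound 3 to compound 4, 1.0-fold (0.00 log units) apart, within the scatter of two such steps. This supports carrying the small size of this step between these two cores in this assay. It rests on two pairs only, with the chloro in a different place on each core, so it gives no general rule for other cores or other positions.

As far as these compounds go, whether an amine or a carboxylic acid in place of the chloro would also leave the read-out unchanged remains open. Also open, from the compounds shown here alone, is whether either core would respond in the same way to such a group.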